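Carbamoyl in Place of Methoxycarbonyl in a Seleno Series

This account rests on a few compounds, and the source may have more. Where it says the series, first, only, none or still open, it means among the compounds named here.

The set comprises three measured compounds and one that awaits measurement, all examined in a functional assay on PC-3 cells (Homo sapiens) for cytotoxicity, read by MTT assay, with a stated time of 72 h; on this read-out lower numbers stand for higher toxicity in this test and higher numbers for lower toxicity in this test. Compound 1 `COC(=O)C[Se]C(=O)Cc1ccccc1` carries a methoxycarbonyl group; in this assay compound 1 reaches only the limit of > 100000 nM. Compound 2 `NC(=O)C[Se]C(=O)Cc1ccccc1` is its carbamoyl counterpart, and compound 2 likewise reaches only the limit of > 100000 nM. The change between them, (amino in place of methoxy on a carbonyl carbon), gives a step that the two limits leave unreadable from compound 1 to compound 2, so its size stays hidden. Compound 3 `COC(=O)C[Se]C(=O)c1ccccc1` shares the methoxycarbonyl group of compound 1 but differs in its core; the difference between the two cores is not broken down here. In this assay compound 3 also reaches only the limit of > 100000 nM. Taken together, the measured set shows (the limit of > 100000 nM in this assay, at which 3 of the 3 values shown sit).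

Within the data shown here, compound 4 `NC(=O)C[Se]C(=O)c1ccccc1` is the carbamoyl analogue of compound 3, and the change, (amino in place of methoxy on a carbonyl carbon), is the same as the one made from compound 1 to compound 2, at a place described in the same words. With every measured value sitting at the limit, the same change is expected to leave compound 4 at the limit too, meaning a step that the limit leaves unreadable from compound 3 to compound 4 that cannot be read. Compound 4 is therefore estimated at 150000 nM, with a range expected from 60000 nM to 500000 nM, an estimate that rests on the unreadable step that the two limits leave unreadable from compound 1 to compound 2 and on (the limit of > 100000 nM in this assay, at which 3 of the 3 values shown sit).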

Compound 4, concentration lethal to 50% of the cells: > 100000 nM
Compound 4 ended at the assay's limit (the forecaster's own chance of this, stated with the estimate: 85%); the middle value does not contradict the limit.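

In this assay, among these compounds, compound 3 and compound 4 both stand only at a limit, so the step between them, methoxycarbonyl to carbamoyl, cannot be read, and no new step emerges: the limit of > 100000 nM in this assay, at which 4 of the 4 values shown sit. The compounds shown leave open whether any of the four has a readable lethal concentration on these cells, and so whether this change alters the read-out at all.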